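The compounds below may be only part of what the source reports. "The series", "measured", "known", "first", "only" and "open" are said of these compounds alone.

In an ADME assay on HEK293 cells (Homo sapiens) for cytotoxicity, with a stated time of 72 h (a lower number here means that less compound is needed, a higher number that more compound is needed for the effect), compound 1 `CSc1ccc(NC(=O)Nc2cc(C)nc3ccccc23)cc1` gives 24000 nM. Compound 2 `CC(=O)c1ccc(NC(=O)Nc2cc(C)nc3ccccc23)cc1` gives > 25000 nM, which is a limit and not a number. Compound 3 `Cc1cc(NC(=O)Nc2ccc(F)cc2)c2ccccc2n1` also gives only a limit, > 25000 nM. This places compound 3 at the limit of > 25000 nM in this assay, at which 2 of the 3 values shown sit. Compound 4 `Cc1cc(NC(=O)Nc2ccc(N(C)C)cc2)c2ccccc2n1` has dimethylamino in place of fluoro on an aromatic carbon, para to a large group: dimethylamino in place of fluoro on an aromatic carbon.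

For the measured compounds named here, three measured steps bear on this change. They are an at least 1.0-fold higher number from compound 1 to compound 2 (0.01 log units; that floor lies within the scatter), an at least 1.0-fold higher number from compound 1 to compound 3 (0.01 log units; that floor lies within the scatter) and a step that the two limits leave unreadable from compound 2 to compound 3. Going by the values given here, none of them shows a change beyond the scatter, and the only number, 24000 nM for compound 1, offers no sign of a large effect from swapping this group. A small downward move or none is therefore expected in this assay, and the expected change is an at least 1.2-fold lower number from compound 3 to compound 4 (0.09 log units; that floor lies within the scatter). For compound 4 the estimated value is 20000 nM. The expected range for compound 4 runs from 8000 nM to 30000 nM.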

Compound 4, half-maximal effective concentration: > 25000 nM
Compound 4 was reported as a limit (the forecaster's own chance of this, stated with the estimate: 55%); middle value at least 1.2-fold (0.09 log units) away from the limit.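

In this assay compound 4 gives > 25000 nM, which is a limit and not a number. For the compounds shown here, the only step that can be read is an at least 1.0-fold higher number from compound 1 to compound 4 (0.01 log units; that floor lies within the scatter), so dimethylamino in place of methylsulfanyl shows no change beyond the scatter, while the steps joining compound 4 to compound 2 and compound 3 cannot be read, as both ends of each are limits. With dimethylamino, this position para to a large group now has a third group, after acetyl and fluoro, that ends at the same limit: the limit of > 25000 nM in this assay, at which 3 of the 4 values shown sit.

On these data alone, how far compound 2, compound 3 and compound 4 lie past that limit stays open, so no order among them can be given. As far as these compounds go, it is also open whether a carboxylic acid or a longer chain at this position would move the number beyond the scatter.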